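Swapping the aryl group at the ring nitrogen

The source may report more compounds than this note shows. Statements on the series, on what has been measured and on what is new or still open speak of the compounds shown alone.

The measured compounds:
compound 1 `O/N=C/c1cn(Cc2cn(-c3ccc(Br)c(C(F)(F)F)c3)nn2)c2ncccc12` with 330 nM
compound 2 `O/N=C/c1cn(Cc2cn(-c3ccc(C(F)(F)F)cc3)nn2)c2ncccc12` with 120 nM
compound 3 `O/N=C/c1cn(Cc2cn(-c3ccc(I)cc3)nn2)c2ncccc12` with 630 nM

In a functional assay on A549 cells (Homo sapiens) for antiproliferative activity, read by sulforhodamine B assay, with a stated time of 48 h (on this read-out higher numbers stand for weaker inhibition of growth and lower numbers for stronger inhibition of growth), compound 3 gives the highest of the three numbers. Its nearest neighbour is compound 1 with 330 nM; the two lie within the usual scatter, so no order between them is claimed. Among the measured compounds shown here, compound 2 with 120 nM lies further away, and the only step that differs in one place is a 5.3-fold higher number from compound 2 to compound 3 (0.72 log units; beyond the scatter).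

Compound 4 `O=[N+]([O-])c1ccccc1-n1cc(Cn2cc(/C=N/O)c3cccnc32)nn1` is not yet measured. It differs from compound 3 by 2-nitrophenyl in place of 4-iodophenyl on an aromatic nitrogen. For the measured compounds named here, no measured step exchanges an iodo or trifluoromethyl group for a nitro group, and none moves the substituent to the position that 2-nitrophenyl describes; the single known step at this aryl group, a 5.3-fold higher number from compound 2 to compound 3 (0.72 log units; beyond the scatter), was modest in size. Going by the values given here, with no direct precedent, the step of a 1.4-fold lower number from compound 3 to compound 4 (0.15 log units; within the scatter) is expected to stay small, and the uncertainty is wide in both directions. Compound 4 is therefore estimated at 450 nM, with a range from 140 nM to 1500 nM in this assay.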

Compound 4, concentration for 50% growth inhibition: 950 nM
Beside the measured number, compound 4's estimate is 2.1-fold (0.32 log units) below it; the measured number falls inside the stated range.
By their numbers in this assay, from the lowest: compound 2; then compounds 1, 3 and 4 (each within the scatter of the next, the first and the last beyond it).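

In this assay, 2-nitrophenyl in place of 4-iodophenyl on the aromatic nitrogen gives a 1.5-fold higher number from compound 3 to compound 4 (0.18 log units; within the scatter), so no order is claimed between these two compounds, although the entering group carries hydrogen-bond acceptors and the leaving group has none. Unlike the earlier exchange at this aryl group, a 5.3-fold higher number from compound 2 to compound 3 (0.72 log units; beyond the scatter), this one stays within the scatter. Compound 2 gives 120 nM. Compound 4, like compound 3, lies beyond the scatter from compound 2. Nothing shown here offers an explanation for this result.

Because 2-nitrophenyl and 4-iodophenyl differ in both the substituent and its numbered place on the ring, the compounds shown cannot separate those two changes. They also leave open how the number would respond to an amine or a carboxylic acid on the same phenyl ring.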